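The compounds below may be only part of what the source reports. "The series", "measured", "known", "first", "only" and "open" are said of these compounds alone.

Three measured compounds frame this step. Compound 1 `COc1ccc2cc(-c3cc4cc(C(C)N(O)C(C)=O)ccc4o3)ccc2c1` is tested in an assay on RBL cells for inhibition of Polyunsaturated fatty acid 5-lipoxygenase (Rattus norvegicus) (a lower number here means a stronger inhibitor, a higher number a weaker inhibitor), and gives 120 nM. Compound 2 `CC(c1ccc2oc(-c3ccccc3)cc2c1)N(O)C(=O)c1ccco1` gives 40 nM in this assay, and compound 3 `CCCCc1cc2cc(C(C)N(O)C(=O)CCCC(=O)OC)ccc2o1` gives 50 nM in this assay. Among these three, compound 2 gives the smallest number, but the reading of compound 3 lies within the usual scatter of repeated measurements, so the two cannot be told apart; only compound 1 stands clearly apart from compound 2, beyond that scatter.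

Compound 4 `CC(c1ccc2oc(-c3ccccc3)cc2c1)N(O)C(=O)CO` is not yet measured. It differs from compound 2 in one place: hydroxymethyl in place of furan-2-yl on a carbonyl carbon. The carbonyl carbon itself stays, attached to the same amide-type nitrogen that carries the hydroxyl group; only the group on the far side of that carbonyl is exchanged.

Among the compounds with values here, no two measured compounds differ in exactly one place, so no measured step exists to lean on. Compound 1 and compound 3, which carry small, ring-free groups on that carbonyl, still show values in the same broad region as compound 2 in this assay, so only a modest step in either direction, or none beyond the scatter, is expected. Compound 4 is estimated at 70 nM in this assay, with a likely range from 25 nM to 200 nM, which corresponds to an expected step of a 1.8-fold higher number from compound 2 to compound 4 (0.24 log units; within the scatter).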

Compound 4, half-maximal inhibitory concentration: 700 nM
Beside the measured number, compound 4's estimate is 10-fold (1.00 log units) below it; the measured number lies above the stated range.
By their numbers in this assay, from the lowest: compounds 2 and 3 (each within the scatter of the next); then compound 1; then compound 4.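

In this assay, exchanging furan-2-yl for hydroxymethyl on a carbonyl carbon gives an 18-fold higher number from compound 2 to compound 4 (1.24 log units; beyond the scatter), a large loss of inhibition. Within the data shown here, this is the first step here between two compounds that differ in one place, so it shows that the group on this carbonyl carbon can by itself move the number well beyond the scatter, even with the shared core and the amide-type nitrogen unchanged. The exchange removes a ring and adds a hydrogen-bond donor at once, and no measurement available here separates those two differences or explains the rise in the number.

Still open, on these data alone, is which of those two differences accounts for the step: a methoxymethyl group on the same carbonyl would test a ring-free group without the hydroxyl, and thiophen-2-yl would test whether another five-membered aromatic ring can stand in for furan-2-yl. As far as these compounds go, it is also open whether a step of this size would appear on the different cores of compound 1 and compound 3, as this single pair speaks only for the core of compound 2.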